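The source may hold more compounds than are shown below. What is called first, only, known or untested is meant among the compounds shown, and "the series" means these compounds.

In a functional assay on NCI-H1299 cells (Homo sapiens) for inhibition, read by CCK-8 assay, with a stated time of 72 h, tested at 10 uM (on this read-out lower numbers stand for less inhibition of growth and higher numbers for more inhibition of growth at the one concentration tested), compound 2 (`CN(C)C(=O)c1cc2cnc(Nc3ccc(NC(=O)C4(C(=O)Nc5ccccc5F)CC4)cc3)nc2n1C1CCCC1`) gives 89.6% and compound 1 (`CN(C)C(=O)c1cc2cnc(Nc3ccc(N)cn3)nc2n1C1CCCC1`) gives 82.1% on the same read-out, two numbers within the usual scatter of each other. Compound 3 (`CN(C)C(=O)c1cc2cnc(Nc3ccc(NC(=O)C4(C(=O)Nc5ccccc5)CC4)cc3)nc2n1C1CCCC1`) differs from compound 2 at one place, with hydrogen in place of fluoro on an aromatic carbon, so that 2-fluorophenyl becomes phenyl (hydrogen in place of fluoro on an aromatic carbon). Among the compounds with values here, no measured pair shows what this swap does, so no step beyond the scatter is expected in this assay for it. The estimated a number 2.6 percentage points lower from compound 2 to compound 3 (within the scatter) is therefore small. Compound 3 is expected to give 87% with a range from 76% to 96% in this measurement.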

Compound 3, percent growth inhibition at one concentration: 90.5%
The estimate for compound 3 lay 3.5 percentage points below the measured number; the measured number falls inside the stated range.
By their numbers in this assay, from the lowest: compounds 1, 2 and 3 (each within the scatter of the next).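

In this assay the change from 2-fluorophenyl to phenyl gives a number 0.9 percentage points higher from compound 2 to compound 3 (within the scatter) so removing this fluoro, on an aromatic carbon ortho to a large group, causes no change this read-out can distinguish. The fluoro is therefore not required for growth inhibition in this single-concentration test. No available evidence explains this result.

Going by these compounds, whether an amine, a methoxy group or a carboxylic acid at this same place would shift the number remains open. So does whether compound 2 and compound 3 would separate at lower concentrations.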